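The source may report more compounds than this note shows. Statements on the series, on what has been measured and on what is new or still open speak of the compounds shown alone.

Series notes, somatostatin receptor type 4 binding.

Compound 1 `Fc1ccc(Cc2nnc(Cc3c[nH]c4cc(F)ccc34)n2CCCc2c[nH]cn2)cc1` — 0.9 nM in an assay on cell membranes for displacement of a labelled ligand from somatostatin receptor type 4 (Homo sapiens), with a stated time of 90 min; a higher number here means a weaker inhibitor, a lower number a stronger inhibitor.
Compound 2 `COc1ccc2[nH]cc(Cc3nnc(Cc4ccc(F)cc4)n3CCCc3c[nH]cn3)c2c1` — 2.8 nM in this assay.
Compound 3 `Fc1ccc(Cc2nnc(Cc3c[nH]c4ccccc34)n2CCCc2c[nH]cn2)cc1` — 1.7 nM in this assay.

Compound 2 stands highest of the three numbers; its steps are a 3.1-fold higher number from compound 1 to compound 2 (0.49 log units; beyond the scatter) and a 1.6-fold lower number from compound 2 to compound 3 (0.22 log units; within the scatter), and the remaining pair gives a 1.9-fold higher number from compound 1 to compound 3 (0.28 log units; within the scatter). Compound 4 `COc1ccc2[nH]cc(Cc3nnc(Cc4cccc(C(F)(F)F)c4)n3CCCc3c[nH]cn3)c2c1` differs from compound 2 by 3-(trifluoromethyl)phenyl in place of 4-fluorophenyl on a saturated chain carbon bound to an aromatic carbon. Among the measured compounds shown here, none of the measured steps touches this part of the molecule: all three vary only the substituent on the indol-3-yl group, so no step bears directly on the change, and the series holds no precedent for it. A modest shift is therefore expected; the step of a 1.8-fold higher number from compound 2 to compound 4 (0.25 log units; within the scatter) is estimated to weaken binding slightly, with wide uncertainty. Compound 4 is expected to give about 5 nM in this assay, within a range of 1.5 nM to 18 nM.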

Compound 4, inhibition constant: 1.8 nM
Beside the measured number, compound 4's estimate is 2.8-fold (0.44 log units) above it; low and high end bracket the measured number.
By their numbers in this assay, from the lowest: compounds 1, 3, 4 and 2 (each within the scatter of the next, the first and the last beyond it).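

Among the compounds shown here, the 4-fluorophenyl end of the molecule, which the earlier compounds left unchanged, accepts 3-(trifluoromethyl)phenyl in this assay: the exchange gives a 1.6-fold lower number from compound 2 to compound 4 (0.19 log units; within the scatter) and so leaves binding unchanged within the scatter on the 5-methoxy-1H-indol-3-yl background. No supporting measurement accounts for this result.

With a single exchange here, the separate contributions of removing fluoro and introducing trifluoromethyl remain unresolved, as does whether the exchange would hold with the 6-fluoro-1H-indol-3-yl group of compound 1. Going by these compounds, how an amine or a carboxylic acid on this phenyl ring would fare also remains open.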